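The source may hold more compounds than are shown below. What is called first, only, known or untested is meant among the compounds shown, and "the series" means these compounds.

Compound 1 `CN(C)CCN1CCN(c2nc(-c3ccccn3)nc3c2CN(Cc2ccccc2)CC3)CC1` reaches 41.3% in an assay on FRT cells with Cystic fibrosis transmembrane conductance regulator variant F508del (Homo sapiens) as the target, read by fluorescence, with a stated time of 25 min; on this read-out higher numbers stand for larger maximal responses and lower numbers for smaller maximal responses. Compound 2 `COc1ccc(CN2CCc3nc(-c4ccccn4)nc(N4CCN(CCN(C)C)CC4)c3C2)cc1`, which carries 4-methoxybenzyl, is recorded in this assay as "not active" (no number reported), so it stands at no single number on this read-out. Compound 3 `CN(C)CCN1CCN(c2nc(-c3ccccn3)nc3c2CN(Cc2ccc(F)cc2)CC3)CC1` differs from compound 2 in one place: fluoro in place of methoxy on an aromatic carbon. Whether this change lifts the largest response in this assay is open, but compound 1, which carries neither methoxy nor fluoro on its benzyl, gives 41.3%, so a step upward beyond the usual scatter seems possible here. Compound 3 is therefore expected to reach about 25%, estimated to lie between 0% and 50%.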

Compound 3, largest response reached (Emax), in percent of the reference or control that the assay uses: "not active" (no number reported)
The entry for compound 3 holds no number, and the estimate cannot be compared.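

Compound 2 and compound 3 are both recorded as not active in this assay, with no number, so no step can be read between them. On these data alone, how far methoxy and fluoro differ on this read-out stays open. Nothing shown here explains this result.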